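The source may report more compounds than this note shows. Statements on the series, on what has been measured and on what is new or still open speak of the compounds shown alone.

Measured so far:
compound 1 `CCCOC(=O)Nc1ccc([Se]C#N)cc1` — 68800 nM
compound 2 `O=C(Nc1ccc([Se][Se]c2ccc(NC(=O)Oc3ccccc3)cc2)cc1)Oc1ccccc1` — 73700 nM

Two compounds carry numbers in a functional assay on CCRF-CEM cells (Homo sapiens) for cytotoxicity, read by MTT assay, with a stated time of 72 h; on this read-out lower numbers stand for higher toxicity in this test and higher numbers for lower toxicity in this test. Compound 1 gives 68800 nM and compound 2 gives 73700 nM. Compound 1 has the lower of the two numbers, yet compound 2 sits within the scatter of it, so nothing can be said about an order between them; both are weak in this assay. Among the compounds with values here, no pair of measured compounds differs in a single place, so no step size is known from the data.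

Compound 3 `CCCCCCOC(=O)Nc1ccc([Se]C#N)cc1` is not yet measured in this assay. It differs from compound 1 in one place: propyl in place of hydrogen on a saturated chain carbon, three bonds along the chain from an oxygen next to a carbonyl group.

Within the data shown here, no step of this kind is known, and the only reference is compound 1 with 68800 nM. A lengthening of the chain by three carbons is expected to move the number little in this assay, with no clear direction; the expected step from compound 1 to compound 3 is a 1.1-fold lower number from compound 1 to compound 3 (0.06 log units; within the scatter), which is within the scatter. Compound 3 is estimated at 60000 nM in this assay, with a range from 25000 nM to 150000 nM.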

Compound 3, concentration lethal to 50% of the cells: 72700 nM
Beside the measured number, compound 3's estimate is 1.2-fold (0.08 log units) below it, within the range that was stated.
By their numbers in this assay, from the lowest: compounds 1, 3 and 2 (each within the scatter of the next).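

Read in this assay, the exchange of hydrogen for propyl on a saturated chain carbon, three bonds along the chain from an oxygen next to a carbonyl group, gives a 1.1-fold higher number from compound 1 to compound 3 (0.02 log units; within the scatter), and this is the first step known in the series. At this position, then, the added propyl leaves compound 3 inseparable from compound 1, so this one change gives no order between the two and no direction for chain length. No measurement in hand bears on why the number holds at this place.

One step of this size cannot show whether the position is insensitive in general or only to this particular saturated chain, since both compounds sit at the same weak level. Open, going by these compounds, are a longer chain than hexyl, a branched chain such as isopropyl or tert-butyl, and a chain ending in an amine or a carboxylic acid, any of which could show whether this place can separate from compound 1 at all.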